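The source may hold more compounds than are shown below. What is called first, only, known or untested is meant among the compounds shown, and "the series" means these compounds.

Compound 1 `CC(C)[C@H](NC(=O)COc1cccc2ccccc12)C(=O)N[C@@H](CC(=O)O)C(=O)COC(=O)c1c(Cl)cccc1Cl`: 10600 nM
Compound 2 `CC(C)[C@H](NC(=O)COc1cccc2ccccc12)C(=O)N[C@@H](CC(=O)O)C(=O)COc1cccc2ccccc12`: > 100000 nM

These values come from a functional assay on Jurkat cells (Homo sapiens); a lower number here means a stronger inhibitor, a higher number a weaker inhibitor. Compound 2 sits at the limit of > 100000 nM in this assay, at which 1 of the 2 values shown sits, so its entry is a limit of the assay and not a number.

Compound 3 `CC(C)[C@H](NC(=O)COc1cccc2ccccc12)C(=O)N[C@@H](CC(=O)O)C(=O)COc1ccc2ccccc2c1` has the same atoms as compound 2, joined differently: naphthalen-2-yl in place of naphthalen-1-yl on an oxygen on a saturated carbon.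

Among the compounds with values here, one measured step touches this place, an at least 9.4-fold higher number from compound 1 to compound 2 (0.97 log units; beyond the scatter), where naphthalen-1-yl replaced (2,6-dichlorophenyl)carbonyl. Within the data shown here, it shows that the group on this oxygen can matter, but it is a different swap, and no pair of naphthalene isomers has been compared. A large gain therefore seems unlikely, and compound 3 is expected to remain weak, close to the limit. The expected change is small: a number no higher from compound 2 to compound 3 (the limit leaves the size open). Compound 3 is estimated at 100000 nM, with an expected range of 30000 nM to 200000 nM.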

Compound 3, half-maximal inhibitory concentration: > 100000 nM
Compound 3: a limit, no number (the forecaster's own chance of this, stated with the estimate: 65%); the middle value lies on the limit itself.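

In this assay compound 3 gives > 100000 nM, which is a limit of the assay and not a number. Changing the attachment point of the naphthalene therefore does not bring back measurable inhibition, and naphthalen-2-yl in place of (2,6-dichlorophenyl)carbonyl on this oxygen gives an at least 9.4-fold higher number from compound 1 to compound 3 (0.97 log units; beyond the scatter), so the loss seen earlier is not confined to the naphthalen-1-yl isomer. The two naphthalene isomers cannot be ranked against each other, since both entries are limits and the step between them cannot be read: the limit of > 100000 nM in this assay, at which 2 of the 3 values shown sit.

Still open, going by these compounds, is which part of the (2,6-dichlorophenyl)carbonyl group matters, the carbonyl or the chlorinated ring. A plain benzoyl group or a 2,6-dichlorophenyl group joined directly to this oxygen would separate the two.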